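Moving the Chlorine on the Phenyl Ring of Compound 1

A few compounds are considered here, and "the series" means these few. Any claim that something is new, unique, unknown or untested is made for them only; others in the source may bear on it.

Measured so far:
compound 1 `O=C(Cn1cc(-c2ccccc2Cl)nn1)Nc1nc2ccccc2s1`: > 30000 nM
compound 2 `CCOC(=O)c1sc(NC(=O)Cn2cc(-c3ccncc3)nn2)nc1C`: 120 nM
compound 3 `Cc1csc(NC(=O)Cn2cc(-c3ccc(C(=O)O)cc3)nn2)n1`: > 30000 nM

All three were tested in a functional assay on BMDM cells (Mus musculus, strain C57BL/6) for inhibition, with a stated time of 2 days; a lower number here means a stronger inhibitor, a higher number a weaker inhibitor. In this assay compound 1 gives > 30000 nM, which is a limit of the assay and not a measured number. Compound 3 likewise returns a limit, > 30000 nM. For the measured compounds named here, compound 2 is the one compound with a real number, 120 nM. Compound 1 therefore stands at the limit of > 30000 nM in this assay, at which 2 of the 3 values shown sit.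

The next compound, compound 4 `O=C(Cn1cc(-c2ccc(Cl)cc2)nn1)Nc1nc2ccccc2s1`, keeps every atom of compound 1 and only rearranges them: 4-chlorophenyl in place of 2-chlorophenyl on an aromatic carbon. Going by the values given here, no pair of measured compounds differs in a single place, so there is no measured step to lean on. What can be said is that compound 1 sits at the limit, and that the change is a shift of one chlorine on one ring. The step from compound 1 to compound 4 is expected to be modest, perhaps toward stronger inhibition but quite possibly none beyond the scatter, as an at least 1.5-fold lower number from compound 1 to compound 4 (0.17 log units; that floor lies within the scatter). Compound 4 is therefore estimated at 20000 nM, with a range from 3000 nM to 30000 nM.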

Compound 4, half-maximal inhibitory concentration: 130 nM
The estimate for compound 4 lay 150-fold (2.19 log units) above the measured number, outside the stated range (below it).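

Where the chlorine sits on the phenyl ring matters greatly for this series: with the rest of the molecule unchanged, 4-chlorophenyl in place of 2-chlorophenyl gives an at least 230-fold lower number from compound 1 to compound 4 (2.36 log units; beyond the scatter) in this assay. The two groups have the same atoms and the same counts of hydrogen-bond donors and acceptors, so a rearrangement within a single group is enough to produce a large change in this read-out. The printed step is only a minimum, because compound 1 has no measured number and sits at a limit: the limit of > 30000 nM in this assay, at which 2 of the 4 values shown sit.

The compounds shown do not explain why the chlorine's place has so large an effect, and a single pair cannot show whether the same change would have a similar effect on a different core. For the compounds shown here, they also leave open whether chlorine itself is needed, since the comparison includes no compound with a fluorine, a methoxy group or a nitrile in place of the chlorine of 4-chlorophenyl.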